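A few compounds are considered here, and "the series" means these few. Any claim that something is new, unique, unknown or untested is made for them only; others in the source may bear on it.

Measured compounds:
compound 1 `COc1ccc2[nH]c(=O)c(-c3nc4cc(C)c(C)cc4[nH]3)cc2c1`: in a functional assay on BEL-7404 cells for cytotoxicity against BEL-7404 tumor cell line (Homo sapiens), read by MTT assay, with a stated time of 48 h (a higher number here means a weaker inhibitor, a lower number a stronger inhibitor), compound 1 gives > 100000 nM, which is a limit of the assay.
compound 2 `Cc1ccc2[nH]c(=O)c(-c3nc4ccccc4[nH]3)cc2c1`: in this assay compound 2 gives > 100000 nM, a limit of the assay.
compound 3 `COc1ccc2[nH]c(=O)c(-c3nc4ccccc4[nH]3)cc2c1`: in this assay compound 3 gives > 100000 nM, a limit of the assay.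

Every value shown sits at the limit of > 100000 nM in this assay, at which 3 of the 3 values shown sit, so no number is known for any of the three. Compound 3 and compound 2 differ in one place, (methyl in place of methoxy on an aromatic carbon), yet the step that the two limits leave unreadable from compound 3 to compound 2 cannot be read because both ends sit at the limit of > 100000 nM in this assay, at which 3 of the 3 values shown sit.

Compound 4 `Cc1ccc2[nH]c(=O)c(-c3nc4cc(C)c(C)cc4[nH]3)cc2c1` has not been measured in this assay. It stands to compound 1 as compound 2 stands to compound 3: the change is methyl in place of methoxy on an aromatic carbon, the same change, at a place described in the same words. The difference between the core of compound 1 and the core of compound 3 is not broken down here. Among the compounds with values here, the only guide is compound 1, whose value is a limit. On that basis the step from compound 1 to compound 4 is expected to be a step that the limit leaves unreadable from compound 1 to compound 4, most likely again only a limit. Compound 4 is therefore estimated at 150000 nM, between 100000 nM and 400000 nM.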

Compound 4, half-maximal inhibitory concentration: > 100000 nM
Compound 4 ended at the assay's limit (the forecaster's own chance of this, stated with the estimate: 85%); the middle value lies beyond the limit too.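

Compound 1 and compound 4 both sit at the assay's limit, so no new step can be read, and the change from methoxy to methyl remains unreadable here as well: the limit of > 100000 nM in this assay, at which 4 of the 4 values shown sit.

The compounds shown leave open whether methyl and methoxy differ at all in effect on this core, and whether any member of the series gives a readable value.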